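The source may report more compounds than this note shows. Statements on the series, on what has been measured and on what is new or still open speak of the compounds shown alone.

For the measured compounds named here, the series is read in a physicochemical assay for acid dissociation, and three compounds have numbers so far. Compound 1 (`COc1cc2cc[nH]c2cc1-c1ccncc1`) stands at 5.8 on this scale, compound 2 (`COc1cc2cn[nH]c2cc1-c1ccncc1`) at 5.4 and compound 3 (`COc1cc2c(C(=O)N3CCN(C)CC3)n[nH]c2cc1-c1ccncc1`) at 5.3 in the same measurement. Compound 3 lies within the scatter of compound 2 and beyond the scatter under compound 1, so these two share the low end of the three numbers.

The next compound is compound 4 (`COc1cc2c(C(=O)N3CCN(C)CC3)n[nH]c2cc1-c1cc(C)nc(C)c1`). It carries 2,6-dimethylpyridin-4-yl in place of pyridin-4-yl on an aromatic carbon, and the shared core is otherwise unchanged. The place of the change is a six-membered aromatic ring of carbon only, part of a fused or bridged system of two rings, ortho to a methoxy group.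

Going by the values given here, no measured pair differs in one place, so the data hold no direct guide to this change, and the expectation rests on the structural change alone. A rise in this assay beyond the scatter is expected, with a number 1.10 log units higher from compound 3 to compound 4 (beyond the scatter) as the estimated size of the step. For compound 4 the estimated value is 6.4 with an expected range from 5.8 to 7 for the coming measurement.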

Compound 4, acid dissociation constant: 6.7
Compound 4: the middle estimate sits 0.30 log units below what was measured; the measured number falls inside the stated range.
By their numbers in this assay, from the lowest: compounds 3 and 2 (each within the scatter of the next); then compound 1; then compound 4.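

In this assay, for the compounds shown here, there is a number 1.40 log units higher from compound 3 to compound 4 (beyond the scatter) with 2,6-dimethylpyridin-4-yl in place of pyridin-4-yl on the aromatic carbon ortho to a methoxy group, the first step that can be read between compounds differing in one place. The step is large although the leaving and entering groups match in ring type, hydrogen-bond donors, hydrogen-bond acceptors and net charge, and differ in heavy atoms only, so this position on the shared core is one where a change within the attached ring alone moves the read-out well beyond the scatter. Nothing in the data at hand speaks to the origin of this step.

Still open, from the compounds shown here alone, is how a ring with a single methyl group would read in this assay, and whether an amine, a methoxy group or a fluorine on the ring would move the number in the same direction. Also open, going by these compounds, is whether the same exchange gives a step of similar size on the core of compound 2, which lacks the amide carried by compound 3 and compound 4.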